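The source may report more compounds than this note shows. Statements on the series, on what has been measured and on what is new or still open speak of the compounds shown alone.

Measured so far:
- compound 1, `Nc1nc(Cl)c2ncn(Cc3ccccc3CCl)c2n1`: 39800 nM
- compound 2, `Nc1nc(Cl)c2ncn(Cc3ccc(CCl)cc3)c2n1`: 14800 nM
- compound 3, `ClCc1cccc(Cn2cnc3nc(Cl)nc(Cl)c32)c1`: 3230 nM

In a functional assay on OVCAR-5 cells (Homo sapiens) for cytotoxicity, read by sulforhodamine B assay, with a stated time of 48 h (on this read-out higher numbers stand for weaker inhibition of growth and lower numbers for stronger inhibition of growth), compound 1 stands at the highest of the three numbers. Compound 2 sits nearest to it, with a number that lies beyond the scatter of repeated measurements, and compound 3 lies furthest away, with a number beyond the scatter as well. Compound 4, `ClCc1ccccc1Cn1cnc2c(Cl)nc(Cl)nc21`, has not yet been measured in this assay. It differs from compound 1 in one place: chloro in place of amino on an aromatic carbon. Among the measured compounds shown here, no measured pair shows this single change on its own, so its size can only be estimated. Compound 1 itself gives 39800 nM. Compound 3 also carries chloro rather than amino, though it differs from compound 1 in other places as well, and compound 3 gives 3230 nM. On that basis the step from compound 1 to compound 4 in this assay is expected to be downward and beyond the scatter, estimated at a 5.0-fold lower number from compound 1 to compound 4 (0.70 log units; beyond the scatter). Compound 4 is accordingly expected to give about 8000 nM in this assay, with a plausible range from 2500 nM to 25000 nM.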

Compound 4, concentration for total growth inhibition: 2950 nM
Estimate against measurement, compound 4: 2.7-fold (0.43 log units) above; measured number inside the range.
By their numbers in this assay, from the lowest: compounds 4 and 3 (each within the scatter of the next); then compound 2; then compound 1.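

In this assay, among the compounds shown here, replacing amino with chloro on the aromatic carbon between two ring nitrogen atoms gives a 13-fold lower number from compound 1 to compound 4 (1.13 log units; beyond the scatter) and is the first change in a single place that can be read directly. The step is large, so this position clearly matters on this read-out when compound 1 is the starting point. The amino group that leaves carries a hydrogen-bond donor and an acceptor and the chloro group that enters carries neither, but nothing measured here connects that difference with the step. On these data alone, what a methoxy group, a dimethylamino group or plain hydrogen would give at this position remains open. As far as these compounds go, it is also open whether the same exchange would give a step of similar size on compound 2, where the chloromethyl group sits elsewhere.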